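Working notes: nitro in place of fluoro

The source may report more compounds than this note shows. Statements on the series, on what has been measured and on what is new or still open speak of the compounds shown alone.

Measured in a functional assay on MCF7 cells (Homo sapiens) for inhibition; on this read-out lower numbers stand for stronger inhibition and higher numbers for weaker inhibition:
compound 1 `CCCCNC(=O)N1CC1C#N`: > 12000 nM (a limit)
compound 2 `N#CC1CN1C(=O)Nc1ccc(F)cc1`: 1900 nM
compound 3 `CC(C)(C)NC(=O)N1CC1C#N`: > 300000 nM (a limit)

In this assay, going by the values given here, compound 2 gives 1900 nM, the only number in the set. The two other results are limits. Not yet measured is compound 4 `N#CC1CN1C(=O)Nc1ccc([N+](=O)[O-])cc1`, which carries nitro in place of fluoro on an aromatic carbon, para to a group of 8 heavy atoms (nitro in place of fluoro on an aromatic carbon). Among the compounds with values here, the only measured step, a step that the two limits leave unreadable from compound 1 to compound 3, has no readable size and concerns tert-butyl in place of butyl on an amide-type nitrogen, so it gives no measure for a change on the aromatic ring. Within the data shown here, no measured step therefore sizes this change, and the expectation rests on compound 2 at 1900 nM with no shift beyond the scatter anticipated. The expected change is a 1.1-fold lower number from compound 2 to compound 4 (0.05 log units; within the scatter). For compound 4 the estimated value is 1700 nM. The expected range for compound 4 runs from 400 nM to 8000 nM.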

Compound 4, half-maximal inhibitory concentration: 3000 nM
Beside the measured number, compound 4's estimate is 1.8-fold (0.25 log units) below it, within the range that was stated.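

In this assay, nitro in place of fluoro on an aromatic carbon, para to a group of 8 heavy atoms, gives a 1.6-fold higher number from compound 2 to compound 4 (0.20 log units; within the scatter). Going by these compounds alone, this position therefore carries either fluoro, with 1 heavy atom and 0 hydrogen-bond acceptors, or nitro, with 3 heavy atoms and 2 hydrogen-bond acceptors, with no difference beyond the scatter; the earlier step on the amide-type nitrogen cannot be read, so this is the first sized change in the set. Nothing available here points to a cause for this step.

On these data alone, how an amine, a carboxylic acid or a methoxy group would read at this same position remains open. Also open, as far as these compounds go, is whether a longer chain on the amide-type nitrogen, or a ring substituent at another position, would shift the number beyond the scatter.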